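A few compounds are considered here, and "the series" means these few. Any claim that something is new, unique, unknown or untested is made for them only; others in the source may bear on it.

Measured so far in a functional assay on HL-60 cells (Homo sapiens) for antiproliferative activity, read by sulforhodamine B assay, with a stated time of 72 h; a lower number here means a stronger inhibitor, a higher number a weaker inhibitor:
compound 1 `CN(C)C(=S)N/N=C/c1ccc2ccccc2n1` gives 50 nM
compound 3 `CC(C)c1cccc(C(C)C)c1NC(=S)N/N=C/c1ccc2ccccc2n1` gives 19500 nM
compound 2 `S=C(N/N=C/c1ccc2ccccc2n1)Nc1ccc(Cl)cc1` gives only a limit, > 100000 nM

Compound 2 therefore stands at the limit of > 100000 nM in this assay, at which 1 of the 3 values shown sits; no number is known for it in this assay. Compound 4 `COc1ccc(NC(=S)N/N=C/c2ccc3ccccc3n2)cc1` differs from compound 2 in one place: methoxy in place of chloro on an aromatic carbon. Among the compounds with values here, no step between measured compounds is available, so the size of this change has to be guessed from the values alone. Compound 3, which also carries a substituted phenyl on the thiourea nitrogen, sits far from compound 1, and compound 2 sits at the limit; the aryl-bearing compounds shown are weak in this assay. On that footing compound 4 is expected to remain weak, and the step of an at least 1.6-fold lower number from compound 2 to compound 4 (0.22 log units; that floor lies within the scatter) is expected to be small, with a fair chance that the assay again reports only a limit. Compound 4 is estimated at 60000 nM, within a range from 10000 nM to 200000 nM.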

Compound 4, half-maximal inhibitory concentration: 43800 nM
The estimate for compound 4 lay 1.4-fold (0.14 log units) above the measured number; low and high end bracket the measured number.
By their numbers in this assay, from the lowest: compound 1; then compound 3; then compound 4. At a limit, above all of these: compound 2.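

In this assay, going from 4-chlorophenyl to 4-methoxyphenyl gives an at least 2.2-fold lower number from compound 2 to compound 4 (0.35 log units; beyond the scatter), so the group on this aromatic carbon does move the number, and by more than the scatter. With methoxy in this place, compound 4 gives a measured number, 43800 nM. The step is therefore a floor and not a full size, and compound 2 remains a limit: the limit of > 100000 nM in this assay, at which 1 of the 4 values shown sits.

The compounds shown do not tell how an amine, a carboxylic acid or a longer alkoxy chain on this aromatic carbon would compare with methoxy. They also leave open how far the step really reaches, and no single-place comparison links compound 2 or compound 4 to compound 1 or compound 3.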